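A Smaller Group on Compound 2

This account rests on a few compounds, and the source may have more. Where it says the series, first, only, none or still open, it means among the compounds named here.

In an ADME assay on the whole organism (strain Sprague-Dawley) for pharmacokinetics, with Rattus norvegicus as the target, using cassette dosing, at a dose of 1 mg/kg by the oral route (on this read-out higher numbers stand for higher oral bioavailability and lower numbers for lower oral bioavailability), compound 1 `COc1ccc(C[C@H]2CC[C@](O)(CC(=O)Nc3ccc4[nH]c(=O)oc4c3)CC2)cc1` gives 16% and compound 2 `O=c1[nH]c2ccc(-c3cc(C[C@]4(O)CC[C@@H](Cc5ccccc5)CC4)no3)cc2o1` gives 8.4%, so these two values lie within the usual scatter of each other. Compound 3 `O=c1ccc(-c2cc(C[C@]3(O)CC[C@@H](Cc4ccccc4)CC3)no2)c[nH]1` differs from compound 2 in one place, the group on an aromatic carbon of the five-membered aromatic ring (a group of 7 heavy atoms (5 carbon, 1 nitrogen, 1 oxygen; one six-membered aromatic ring with 1 hetero atom) in place of a group of 10 heavy atoms (7 carbon, 1 nitrogen, 2 oxygen; one five-membered aromatic ring with 2 hetero atoms, one six-membered aromatic ring of carbon only), on an aromatic carbon). Going by the values given here, no measured step of this kind exists to guide a prediction. The estimated step of a number 6.6 percentage points higher from compound 2 to compound 3 (within the scatter) in this assay is therefore expected to stay within the scatter. For compound 3 the expected value is 15%, with an estimated range of 5% to 35%.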

Compound 3, oral bioavailability: 53.1%
Estimate against measurement, compound 3: 38.1 percentage points below; measured number above the stated range.
By their numbers in this assay, from the lowest: compounds 2 and 1 (each within the scatter of the next); then compound 3.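

In this assay, the group on the aromatic carbon next to the ring oxygen turns out to matter. Putting the group of 7 heavy atoms, with its one six-membered aromatic ring, in place of the group of 10 heavy atoms gives a number 44.7 percentage points higher from compound 2 to compound 3 (beyond the scatter). Going by these compounds alone, this is the first readable step at this position, so a smaller group here can change the read-out strongly.

From the compounds shown here alone, whether a plain phenyl ring or a pyridine ring without the carbonyl would keep this gain remains open. No measurement shown gives a cause for the rise.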